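The source may report more compounds than this note shows. Statements on the series, on what has been measured and on what is new or still open speak of the compounds shown alone.

Compounds measured so far in a functional assay on TK-10 cells (Homo sapiens) for inhibition, read by sulforhodamine B assay, with a stated time of 48 h; a lower number here means a stronger inhibitor of growth, a higher number a weaker inhibitor of growth:

Compound 1 `COc1cc(-c2cc(/C=C/C(=O)c3ccc(N)cc3)[nH]n2)cc(OC)c1OC` — 4840 nM
Compound 2 `COc1cc(-c2cc(/C=C/C(=O)c3ccc(Cl)c(Cl)c3)[nH]n2)cc(OC)c1OC` — 8340 nM
Compound 3 `COc1ccc(-c2cc(/C=C/C(=O)c3cc(OC)c(OC)c(OC)c3)[nH]n2)cc1OC` — 3270 nM

Compound 2 gives the highest number of the three in this assay. Going by the values given here, its nearest neighbour is compound 1, which in this assay gives 4840 nM, a gap that lies within the scatter; compound 3, giving 3270 nM in this assay, sits furthest from it, beyond the scatter, though compound 3 also differs from compound 2 at the other end of the shared core, so no single step joins them.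

Compound 4 `COc1ccc(C(=O)/C=C/c2cc(-c3cc(OC)c(OC)c(OC)c3)n[nH]2)cc1` differs from compound 2 in one place: 4-methoxyphenyl in place of 3,4-dichlorophenyl on a carbonyl carbon.

Among the compounds with values here, the one measured step at this position, a 1.7-fold higher number from compound 1 to compound 2 (0.24 log units; within the scatter), stayed within the scatter. It is therefore expected that the step from compound 2 to compound 4 in this assay is likewise small, if anything toward a lower number, estimated as a 1.5-fold lower number from compound 2 to compound 4 (0.18 log units; within the scatter). Compound 4 is accordingly estimated at 5500 nM in this assay, with a range from 2500 nM to 12000 nM.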

Compound 4, concentration for 50% growth inhibition: 2220 nM
Compound 4: the middle estimate sits 2.5-fold (0.39 log units) above what was measured, outside the stated range (below it).
By their numbers in this assay, from the lowest: compounds 4, 3, 1 and 2 (each within the scatter of the next, the first and the last beyond it).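

In this assay, the group on the carbonyl carbon proves able to shift the number beyond the scatter: the change from 3,4-dichlorophenyl to 4-methoxyphenyl gives a 3.8-fold lower number from compound 2 to compound 4 (0.57 log units; beyond the scatter), and methoxy in place of amino on an aromatic carbon gives a 2.2-fold lower number from compound 1 to compound 4 (0.34 log units; beyond the scatter). The earlier step at this position showed no such shift, as compound 1 and compound 2 lay within the scatter of each other, whereas compound 4 now stands apart from both. No measurement shown here explains the difference.

On these data alone, whether a hydroxy group or a carboxylic acid in place of the methoxy on that aromatic carbon would keep the lower number remains open. So does the effect of a single chlorine on the phenyl ring, which would separate the contribution of the two chlorines in compound 2.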